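From a thiadiazole to a triazole on the shared core

The source may hold more compounds than are shown below. What is called first, only, known or untested is meant among the compounds shown, and "the series" means these compounds.

The shared core carries a carboxy group and a hydroxy group on a six-membered ring of carbon only, with a five-membered ring attached. Compound 1 `O=C(O)c1cc(-n2cccc2)ccc1O` bears a pyrrole, and in a functional assay on the whole organism for inhibition, with Rattus norvegicus as the target, read by paw edema (on this read-out higher numbers stand for an effect only at larger amounts of compound and lower numbers for an effect already at smaller amounts), compound 1 gives 50 mg/kg. Compound 2 `O=C(O)c1cc(-n2ccnc2)ccc1O` bears an imidazole; in this assay compound 2 gives 75 mg/kg, and a 1.5-fold higher number from compound 1 to compound 2 (0.18 log units; within the scatter). Compound 3 `O=C(O)c1cc(-c2csnn2)ccc1O` bears a thiadiazole. In this assay compound 3 reaches only a limit of the assay, > 200 mg/kg, so no exact number is known for it (the limit of > 200 mg/kg in this assay, at which 1 of the 3 values shown sits). Among the numbers shown, compound 3 stands apart: an at least 4.0-fold higher number from compound 1 to compound 3 (0.60 log units; beyond the scatter) and an at least 2.6-fold higher number from compound 2 to compound 3 (0.42 log units; beyond the scatter).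

Compound 4 `O=C(O)c1cc(-n2ccnn2)ccc1O` is not yet measured. It differs from compound 3 in one place: 1H-1,2,3-triazol-1-yl in place of 1,2,3-thiadiazol-4-yl on an aromatic carbon. The ring that enters, like the rings of compound 1 and compound 2, is an azole named by its nitrogen, and both of those compounds gave numbers inside the range of the assay. The two steps that bear on this change are the ones leading from compound 1 and from compound 2 to compound 3, both beyond the scatter toward higher numbers. Going the other way, a step toward a lower number is expected for compound 4: an at least 2.2-fold lower number from compound 3 to compound 4 (0.34 log units; beyond the scatter). Compound 4 is therefore estimated at 90 mg/kg, within a range from 40 mg/kg to 200 mg/kg.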

Compound 4, dose for half-maximal effect: 150 mg/kg
Compound 4: middle estimate off by 1.7-fold (0.22 log units), on the low side, within the range that was stated.
By their numbers in this assay, from the lowest: compounds 1, 2 and 4 (each within the scatter of the next, the first and the last beyond it). At a limit, above all of these: compound 3.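

Swapping the thiadiazole for the triazole, on the aromatic carbon para to a hydroxy group and meta to a carboxy group, gives an at least 1.3-fold lower number from compound 3 to compound 4 (0.12 log units; that floor lies within the scatter). Compound 3 stands at a limit of the assay, and the true size of this step stays unknown because the value for compound 3 is no exact number: the limit of > 200 mg/kg in this assay, at which 1 of the 4 values shown sits. Among the rings joined through nitrogen, the triazole cannot be told apart from the imidazole, with a 2.0-fold higher number from compound 2 to compound 4 (0.30 log units; within the scatter), yet it does separate from the pyrrole, with a 3.0-fold higher number from compound 1 to compound 4 (0.48 log units; beyond the scatter), the first step beyond the scatter among these three rings.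

On these data alone, whether the thiadiazole truly differs from the triazole remains open, since an exact number for compound 3 would be needed to settle it. All four groups at this position are five-membered aromatic rings, so the compounds shown say nothing about how a six-membered pyridine ring, a simple amine or a longer alkyl chain would behave in the same place.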